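Methyl for Fluoro on the Urea Aryl of Compound 1

A few compounds are considered here, and "the series" means these few. Any claim that something is new, unique, unknown or untested is made for them only; others in the source may bear on it.

This account concerns three thienopyrimidine ureas measured in a functional assay on MDA-MB-231 cells (Homo sapiens) for cytotoxicity, read by MTT assay, with a stated time of 72 h (on this read-out lower numbers stand for stronger inhibition and higher numbers for weaker inhibition), and a fourth analogue awaiting measurement. Compound 1 `CN(C)CCCNc1nc(-c2ccc(NC(=O)Nc3ccc(F)cc3)cc2)nc2c(Cl)c(Cl)sc12` gives 980 nM in this assay. Compound 2 `CN(C)CCCNc1nc(-c2ccc(NC(=O)Nc3ccc(Cl)cc3Cl)cc2)nc2ccsc12` gives 1860 nM, and compound 3 `CN(C)CCNc1nc(-c2ccc(NC(=O)Nc3ccc(F)cc3)cc2)nc2ccsc12` gives 540 nM. Compound 1 thus holds the second highest of the three numbers; its separation from compound 3 and from compound 2 both fall within the usual scatter, so none of the three can be ranked against the others with confidence.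

Compound 4 `Cc1ccc(NC(=O)Nc2ccc(-c3nc(NCCCN(C)C)c4sc(Cl)c(Cl)c4n3)cc2)cc1` is derived from compound 1 by the change (methyl in place of fluoro on an aromatic carbon), that is, methyl in place of fluoro on an aromatic carbon of a six-membered aromatic ring of carbon only. Going by the values given here, no measured pair among the three compounds isolates this exchange, so the direction of its effect in this assay is not known from the data at hand. The three measured numbers all sit close together despite differences in the urea aryl and the amine chain, which argues against a large shift.

Compound 4 is therefore expected to give about 950 nM, within a range of 400 nM to 2300 nM, the estimated step from compound 1 to compound 4 being a 1.0-fold lower number from compound 1 to compound 4 (0.01 log units; within the scatter), not beyond the scatter.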

Compound 4, half-maximal inhibitory concentration: 4980 nM
Compound 4: the middle estimate sits 5.2-fold (0.72 log units) below what was measured, and the stated range ends below it.
By their numbers in this assay, from the lowest: compounds 3, 1 and 2 (each within the scatter of the next, the first and the last beyond it); then compound 4.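

Going by these compounds alone, the exchange of fluoro for methyl on the urea aryl, on an aromatic carbon para to a large group, is the first change here that can be read on its own: in this assay it gives a 5.1-fold higher number from compound 1 to compound 4 (0.71 log units; beyond the scatter), a modest step that lies beyond the scatter. A higher number stands for weaker inhibition, so this position is not indifferent to which of these two single-atom groups it carries, even though fluoro and methyl each count as one heavy atom with no hydrogen-bond donors or acceptors. Nothing available explains this step.

Within the data shown here, the single step cannot say whether leaving fluoro or entering methyl matters more; hydrogen, chloro, methoxy or ethyl at the same place would be needed to tell how the read-out follows the group there. Going by these compounds, it also remains open whether methyl in place of fluoro would give a step of similar size and direction on compound 3, which carries a different amine chain and lacks the two chlorines on the core.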